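Hydroxymethyl added to the furan of compound 3

The compounds below may be only part of what the source reports. "The series", "measured", "known", "first", "only" and "open" are said of these compounds alone.

Three hydrazones share one core. In an assay on liver (Sus scrofa) for inhibition of glucose-6-phosphatase catalytic subunit 1 (Homo sapiens), using microsomes (a lower number here means a stronger inhibitor, a higher number a weaker inhibitor), compound 1 `Clc1ccc(/C=N/N(Cc2ccccc2)Cc2ccccc2)cc1` gives 240 nM; compound 2 `Clc1ccc(/C=N/N(Cc2ccccc2)Cc2ccccc2)cc1Cl` gives 2000 nM; compound 3 `C(=N/N(Cc1ccccc1)Cc1ccccc1)\c1ccco1` gives 1100 nM. Compound 3 stands second highest of the three numbers: against compound 2 the step of a 1.8-fold lower number from compound 2 to compound 3 (0.26 log units; within the scatter) is within the scatter, against compound 1 the step of a 4.6-fold higher number from compound 1 to compound 3 (0.66 log units; beyond the scatter) is beyond it. Within the measured set, the one step that adds a group to an aromatic ring is an 8.3-fold higher number from compound 1 to compound 2 (0.92 log units; beyond the scatter), a chloro onto a phenyl ring.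

Compound 4 `OCc1ccc(/C=N/N(Cc2ccccc2)Cc2ccccc2)o1` differs from compound 3 in one place: hydroxymethyl in place of hydrogen on an aromatic carbon. Among the measured compounds shown here, no measured step adds a group to the furan, and none adds a hydroxymethyl anywhere, so the single substituent step above bears on this one only loosely, through a different group on a different ring. The expectation for compound 4 is therefore a number in the range of compound 3 or somewhat higher, a step of a 1.4-fold higher number from compound 3 to compound 4 (0.13 log units; within the scatter). Compound 4 is estimated at 1500 nM, within 400 nM to 6000 nM.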

Compound 4, half-maximal inhibitory concentration: 16000 nM
Compound 4: the middle estimate sits 11-fold (1.03 log units) below what was measured, and the stated range ends below it.
By their numbers in this assay, from the lowest: compound 1; then compounds 3 and 2 (each within the scatter of the next); then compound 4.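

In this assay, hydroxymethyl in place of hydrogen on the furan, next to the ring oxygen, gives a 15-fold higher number from compound 3 to compound 4 (1.16 log units; beyond the scatter) and is the only step shown that adds a group to this ring. Compound 2 and compound 3 lie within the scatter of each other, yet 5-(hydroxymethyl)furan-2-yl sits well apart from 3,4-dichlorophenyl in an 8.0-fold higher number from compound 2 to compound 4 (0.90 log units; beyond the scatter) and from 4-chlorophenyl in a 67-fold higher number from compound 1 to compound 4 (1.82 log units; beyond the scatter) as well. This place on the furan is therefore sensitive to substitution: a group of 2 heavy atoms is enough to make compound 4 the weakest of the four in this assay.

A methyl, a methoxymethyl or a carboxylic acid on the same carbon would show whether the loss follows the hydroxyl or any group at this place. No measurement shown here accounts for the loss.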